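The source may hold more compounds than are shown below. What is called first, only, known or untested is meant among the compounds shown, and "the series" means these compounds.

In a functional assay on A549 cells (Homo sapiens) for antiproliferative activity, read by MTT assay, with a stated time of 72 h (a higher number here means a weaker inhibitor, a lower number a stronger inhibitor), compound 1 `Nc1ccccc1NC(=O)CCCCCCc1nc(-c2ccc(C(F)(F)F)cc2)no1` stands at > 100000 nM, which is a limit of the assay and not a number (the limit of > 100000 nM in this assay, at which 1 of the 2 values shown sits). Compound 2 `Nc1ccccc1NC(=O)CCCCCCc1nc(-c2ccc(Cl)cc2)no1` gives 13800 nM. Within the data shown here, the only measured step, an at least 7.2-fold lower number from compound 1 to compound 2 (0.86 log units; beyond the scatter), swaps chloro for trifluoromethyl on an aromatic carbon, so it bears only indirectly on compound 3 `O=C(CCCCCCc1nc(-c2ccc(C(F)(F)F)cc2)no1)C(F)(F)F`. That compound differs from compound 1 at another place: trifluoromethyl in place of (2-aminophenyl)amino on a carbonyl carbon. Among the measured compounds shown here, no measured step covers this change, so only a modest shift is expected. The estimated step is an at least 1.6-fold lower number from compound 1 to compound 3 (0.22 log units; that floor lies within the scatter), expected toward a lower number. For compound 3 the expected value is 60000 nM, with an estimated range of 15000 nM to 100000 nM.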

Compound 3, half-maximal inhibitory concentration: 28800 nM
Beside the measured number, compound 3's estimate is 2.1-fold (0.32 log units) above it; the range from low to high includes it.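

In this assay, the carbonyl carbon proves to be a place where a change moves the result: trifluoromethyl in place of (2-aminophenyl)amino gives an at least 3.4-fold lower number from compound 1 to compound 3 (0.54 log units; beyond the scatter). The (2-aminophenyl)amino group is therefore not required for a measurable value on this core. Compound 1 stands at a limit of the assay, so this step is only a floor: the limit of > 100000 nM in this assay, at which 1 of the 3 values shown sits.

From the compounds shown here alone, whether a carboxylic acid or a simple amine on that carbonyl carbon would serve equally stays open. So does whether chloro in place of the aromatic trifluoromethyl would also lower the number for compound 3.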